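This account rests on a few compounds, and the source may have more. Where it says the series, first, only, none or still open, it means among the compounds named here.

Compound 1 `O=C1C2CCCN2C(=O)N1CN1CCN(c2ccc(F)cc2)CC1` and compound 2 `O=C1C2CCCN2C(=O)N1CN1CCN(c2ccc([N+](=O)[O-])cc2)CC1` share one core, while compound 3 `O=C1C2CCCN2C(=O)N1CCN1CCN(c2ccc(F)cc2)CC1` and compound 4 `O=C1C2CCCN2C(=O)N1CCN1CCN(c2ccc([N+](=O)[O-])cc2)CC1` share another; the difference between the two cores is not broken down here. In an assay on isolated protein for binding affinity to Adrenergic receptor alpha-1 (Rattus norvegicus), read by radioligand binding (a higher number here means a weaker inhibitor, a lower number a stronger inhibitor), compound 1 reaches only a limit, > 1000 nM. Compound 2 likewise reaches only a limit, > 10000 nM. Compound 3 also stops at a limit, > 1000 nM. The change from compound 1 to compound 2, (nitro in place of fluoro on an aromatic carbon), produced a step that the two limits leave unreadable from compound 1 to compound 2, as the two values sit at the limit of > 1000 nM in this assay, at which 2 of the 3 values shown sit, and (the limit of > 10000 nM in this assay, at which 1 of the 3 values shown sits). The same change is made from compound 3 to compound 4, (nitro in place of fluoro on an aromatic carbon), and both place lines read alike. Compound 4 is expected to give 15000 nM. The expected step that the limit leaves unreadable from compound 3 to compound 4 rests on the unreadable a step that the two limits leave unreadable from compound 1 to compound 2, which gives no sign that the nitro group tightens binding.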

Compound 4, inhibition constant: > 10000 nM
Compound 4 ended at the assay's limit; the forecaster's own chance of this, stated with the estimate: 80%; the middle value is on the limit's open side.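

For the compounds shown here, compound 3 and compound 4 both end at limits of the assay, not at numbers, so no step between them can be read. The compounds shown leave open how strongly any of them binds in this assay.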